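The source may report more compounds than this note shows. Statements on the series, on what has been measured and on what is new or still open speak of the compounds shown alone.

Measured so far in an assay on isolated protein with Bile acid receptor (Homo sapiens) as the target; a lower number here means that less compound is needed, a higher number that more compound is needed for the effect:
compound 1 `COC(=O)/C=C/c1cccc(N(Cc2ccc(-c3c(OC)cccc3OC)cc2)C(=O)C2CCCCC2)c1` gives 77 nM
compound 2 `COC(=O)/C=C/c1cccc(N(Cc2ccc(-c3c(OC)cccc3OC)cc2)C(=O)C(C)C)c1` gives 95 nM
compound 3 `COC(=O)/C=C/c1cccc(N(Cc2ccc(/C=C/C(=O)OC(C)(C)C)cc2OC(=O)c2ccccc2)C(=O)C2CCCCC2)c1` gives > 1000 nM — a limit of this assay, not a number

Among the compounds with values here, compound 1 sits at the lowest of the two numbers given; the nearest is compound 2, and the only measured step, a 1.2-fold higher number from compound 1 to compound 2 (0.09 log units; within the scatter), lies within the scatter. Compound 3, which carries a different group where compound 1 has the 2,6-dimethoxyphenyl and also differs elsewhere, gives only the limit (the limit of > 1000 nM in this assay, at which 1 of the 3 values shown sits).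

Compound 4 `COC(=O)/C=C/c1cccc(N(Cc2ccc(/C=C/c3ccc(F)cc3)cc2)C(=O)C2CCCCC2)c1` is to be measured in this assay. It differs from compound 1 in one place: 2-(4-fluorophenyl)ethenyl in place of 2,6-dimethoxyphenyl on an aromatic carbon. Within the data shown here, no measured step covers this change. The only related observation is that compound 3, altered at the same position among others, gives no number, whereas compound 1 gives a number. On its own that is not a step, and for compound 4 it carries little weight for the direction of the step that is expected here, a 3.9-fold higher number from compound 1 to compound 4 (0.59 log units; beyond the scatter).

Compound 4 is therefore expected to fall somewhat weaker than compound 1, with wide uncertainty, at an estimated 300 nM and a range of 80 nM to 1500 nM, which includes the possibility that only a limit is reported.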

Compound 4, half-maximal effective concentration: 185 nM
For compound 4 the middle estimate is 1.6-fold (0.21 log units) above the measured one; the range from low to high includes it.
By their numbers in this assay, from the lowest: compounds 1, 2 and 4 (each within the scatter of the next, the first and the last beyond it). At a limit, above all of these: compound 3.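

In this assay, the position para to a large group still gives a measured number when the 2,6-dimethoxyphenyl is replaced by the longer 2-(4-fluorophenyl)ethenyl, with a 2.4-fold higher number from compound 1 to compound 4 (0.38 log units; beyond the scatter). The entering group has no hydrogen-bond acceptors and the leaving group has two, so a number in this range at this position does not depend on the two methoxy oxygens, although the modest step beyond the scatter shows that the exchange is not neutral. No measurement shown accounts for this step.

The change combines three differences: the ethenyl link, the fluorine and the loss of both methoxy groups, and the compounds shown do not separate them. As far as these compounds go, a directly attached 4-fluorophenyl, an unsubstituted 2-phenylethenyl, or a 2-(4-fluorophenyl)ethyl chain at this position would show which part carries the step, and the isopropyl amide of compound 2 remains open in combination with the 2-(4-fluorophenyl)ethenyl group.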